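Fluoro in place of hydrogen: from compound 3 to compound 4

The compounds below may be only part of what the source reports. "The series", "measured", "known", "first", "only" and "open" are said of these compounds alone.

Measured so far in a functional assay on the whole organism (aorta) with Rattus norvegicus as the target; a lower number here means a smaller maximal response, a higher number a larger maximal response:
compound 1 `O=C1C(Nc2ccc(F)cc2)=CC(=O)c2ncccc21` gives 79%
compound 2 `O=C1C(Nc2cccc(F)c2)=CC(=O)c2ncccc21` gives 85%
compound 3 `O=C1C=C(Nc2ccccc2)C(=O)c2cnccc21` gives 93%

Compound 3 holds the highest of the three numbers in this assay. Its gap to compound 2 lies within the scatter, so no order between those two can be read; its gap to compound 1 lies beyond the scatter.

Compound 4 `O=C1C=C(Nc2ccc(F)cc2)C(=O)c2cnccc21` has not been measured. It differs from compound 3 in one place: fluoro in place of hydrogen on an aromatic carbon. Among the measured compounds shown here, no measured pair shows this exact step with the same core, so its size is open. A small downward step, or none beyond the scatter, is expected in this assay, since compound 1 gives 79% carrying fluoro para to a large group and compound 2 gives 85% carrying fluoro on the same ring.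

For compound 4 the expected value in this assay is 85%, within 72% to 97%, which means an estimated step of a number 8 percentage points lower from compound 3 to compound 4 (within the scatter).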

Compound 4, largest response reached (Emax), in percent of the reference or control that the assay uses: 72%
The estimate for compound 4 lay 13 percentage points above the measured number; the measured number falls inside the stated range.
By their numbers in this assay, from the lowest: compounds 4, 1, 2 and 3 (each within the scatter of the next, the first and the last beyond it).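

In this assay, among the compounds shown here, fluoro in place of hydrogen on the aromatic carbon para to a large group gives a number 21 percentage points lower from compound 3 to compound 4 (beyond the scatter) as the first single-place step. For the compounds shown here, the earlier compounds differ from one another in more than one place, so only this pair shows that the position responds to a one-atom change on the core of compound 3. Nothing at hand accounts for the size of this step.

Open, as far as these compounds go, is whether a chlorine atom, a methoxy group or an amine on the same carbon moves the maximal response in the same direction. Also open, from the compounds shown here alone, is whether the fluoro step holds on the core of compound 1.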